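A few compounds are considered here, and "the series" means these few. Any claim that something is new, unique, unknown or untested is made for them only; others in the source may bear on it.

Working notes on the series.

Compound 1 `Cc1ccc(S(=O)(=O)N2C/C(=C\c3cccnc3)C(=O)/C(=C/c3ccccc3F)C2)cc1` gives 4200 nM in a functional assay on HepG2 cells (Homo sapiens) for cytotoxicity, read by MTT assay, with a stated time of 24 h; a higher number here means a weaker inhibitor, a lower number a stronger inhibitor. Compound 2 `O=C1/C(=C/c2cccnc2)CN(S(=O)(=O)c2ccc([N+](=O)[O-])cc2)C/C1=C\c1ccccc1F` gives 12800 nM in this assay, and compound 3 `Cc1ccc(S(=O)(=O)N2C/C(=C\c3ccncc3)C(=O)/C(=C/c3ccccc3F)C2)cc1` gives 9700 nM. Compound 2 differs from compound 1 by nitro in place of methyl on an aromatic carbon; that change made a 3.0-fold higher number from compound 1 to compound 2 (0.48 log units; beyond the scatter). Compound 3 differs from compound 1 by pyridin-4-yl in place of pyridin-3-yl on a double-bonded chain carbon bound to a double-bonded ring carbon, which made a 2.3-fold higher number from compound 1 to compound 3 (0.36 log units; beyond the scatter). The values of compound 2 and compound 3 lie close together, and nothing further is drawn from that pair.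

Compound 4 `O=C1/C(=C/c2ccncc2)CN(S(=O)(=O)c2ccc([N+](=O)[O-])cc2)C/C1=C\c1ccccc1F` has not yet been measured in this assay. It differs from compound 3 by nitro in place of methyl on an aromatic carbon, the same change as that from compound 1 to compound 2, here made on the core of compound 3 rather than that of compound 1; the two cores differ by pyridin-4-yl in place of pyridin-3-yl on a double-bonded chain carbon bound to a double-bonded ring carbon. Going by the values given here, there is only one earlier instance of the change, a 3.0-fold higher number from compound 1 to compound 2 (0.48 log units; beyond the scatter). Set beside that earlier step, the expected step is estimated as a 2.7-fold higher number from compound 3 to compound 4 (0.43 log units; beyond the scatter). On that basis compound 4 is expected to give 26000 nM in this assay, estimated to fall between 12000 nM and 55000 nM.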

Compound 4, half-maximal inhibitory concentration: 11300 nM
Compound 4: the middle estimate sits 2.3-fold (0.36 log units) above what was measured; measured number below the stated range.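

Nitro in place of methyl, carried onto the core of compound 3, gives a 1.2-fold higher number from compound 3 to compound 4 (0.07 log units; within the scatter), and the gap to the earlier step does not exceed what two such steps can scatter: the same change on two cores in this assay, a 3.0-fold higher number (0.48 log units; beyond the scatter) from compound 1 to compound 2 and a 1.2-fold higher number (0.07 log units; within the scatter) from compound 3 to compound 4, 2.6-fold (0.42 log units) apart, within the scatter of two such steps

Pyridin-4-yl in place of pyridin-3-yl, read on the nitro compounds, gives a 1.1-fold lower number from compound 2 to compound 4 (0.05 log units; within the scatter), and it compares with its earlier step in the same way: the same change on two cores in this assay, a 2.3-fold higher number (0.36 log units; beyond the scatter) from compound 1 to compound 3 and a 1.1-fold lower number (0.05 log units; within the scatter) from compound 2 to compound 4, 2.6-fold (0.42 log units) apart, within the scatter of two such steps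

Going by these compounds alone, for either change the two cores cannot be told apart, but with only one pair of steps per change this shows neither that a step carries over unchanged nor that it depends on the core, even though each step is beyond the scatter on one core and within it on the other.

Still open, from the compounds shown here alone, is whether an amine or a methoxy group in the place of methyl and nitro would follow the same steps on both cores. Going by these compounds, all four values also come from this assay alone, so whether these steps hold in any other test remains open.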